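Adding ethyl to compound 3: working notes

The source may report more compounds than this note shows. Statements on the series, on what has been measured and on what is new or still open speak of the compounds shown alone.

In a functional assay (aorta) for inhibition, with Rattus norvegicus as the target, with a stated time of 8 days (on this read-out lower numbers stand for stronger inhibition and higher numbers for weaker inhibition), compound 1 (`Cc1nsc(-c2ccc(N3CCN(c4cccc(Cl)c4)CC3)nn2)n1`) gives 0.6 nM and compound 3 (`FC(F)(F)c1cccc(N2CCN(c3ccc(-c4ncns4)nn3)CC2)c1`) gives 70 nM, the higher of the two numbers, with the gap beyond the scatter. Compound 2 (`Cc1nsc(-c2ccnc(N3CCN(c4cccc(C(F)(F)F)c4)CC3)n2)n1`), which also bears a group on the matching aromatic carbon, gives only a limit, > 100 nM. Compound 4 (`CCc1nsc(-c2ccc(N3CCN(c4cccc(C(F)(F)F)c4)CC3)nn2)n1`) arises from compound 3 by one change: ethyl in place of hydrogen on an aromatic carbon. Within the data shown here, no measured step isolates this change. Among the measured compounds shown here, the only support is compound 1 at 0.6 nM, which has a group on that carbon but differs elsewhere too. In this assay the expected step of a 3.5-fold lower number from compound 3 to compound 4 (0.54 log units; beyond the scatter) points to a lower number, beyond the scatter. For compound 4 the estimated value is 20 nM, with a range of 3 nM to 100 nM.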

Compound 4, half-maximal inhibitory concentration: 8 nM
For compound 4 the middle estimate is 2.5-fold (0.40 log units) above the measured one; low and high end bracket the measured number.
By their numbers in this assay, from the lowest: compound 1; then compound 4; then compound 3. At a limit, above all of these: compound 2.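

In this assay ethyl in place of hydrogen on the aromatic carbon between two ring nitrogen atoms gives an 8.8-fold lower number from compound 3 to compound 4 (0.94 log units; beyond the scatter) and so a group on this carbon goes with a lower number. Among these compounds, this is the first step that isolates the change, as compound 1 differs elsewhere too. Nothing measured here accounts for the size of this step.

As far as these compounds go, whether a longer chain such as propyl, an amine or a carboxylic acid on this carbon would give a lower or higher number remains open. A single step shows no trend with group size.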